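A few compounds are considered here, and "the series" means these few. Any claim that something is new, unique, unknown or untested is made for them only; others in the source may bear on it.

Measured so far:
Compound 1 (`COC1=C(C)C(=O)/C(=C(O)/C=C/c2ccc(F)cc2)C(=O)C1(C)C`) gives < 4 ug/mL as a limit
Compound 2 (`COC1=C(C)C(=O)/C(=C(O)/C=C/c2c(C)cc(C)cc2C)C(=O)C1(C)C`) gives < 4 ug/mL as a limit
Compound 3 (`COC1=C(C)C(=O)/C(=C(O)/C=C/c2cccc3ccccc23)C(=O)C1(C)C`) gives < 4 ug/mL as a limit

In a functional assay on HUVEC cells (Homo sapiens) (a higher number here means that more compound is needed for the effect, a lower number that less compound is needed), compound 1 gives < 4 ug/mL as its reading, which is a limit of the assay and not a number. All the measured compounds sit at this same limit (the limit of < 4 ug/mL in this assay, at which 3 of the 3 values shown sit), so compound 1 has no exact place among them.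

The next compound to be tested is compound 4 (`COC1=C(C)C(=O)/C(=C(O)/C=C/c2ccco2)C(=O)C1(C)C`). It keeps the shared core and carries furan-2-yl in place of 4-fluorophenyl on a double-bonded chain carbon bound to a double-bonded chain carbon.

Going by the values given here, no measured pair here differs in one place only, so the data give no direct size for such a step. In this assay no step beyond the usual scatter is expected, and no direction is favoured, so the estimated change is small (a step that the limit leaves unreadable from compound 1 to compound 4). This expectation rests on compound 1 with its limit of < 4 ug/mL as the only anchor. The assay may well report only a limit for compound 4 too. If a number is reported, the estimate for compound 4 is 3 ug/mL with an expected range from 1 ug/mL to 8 ug/mL as its two ends.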

Compound 4, concentration for half-maximal effect: < 4 ug/mL
Compound 4: only a limit was reported (the forecaster's own chance of this, stated with the estimate: 65%); the middle value lies beyond the limit too.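

In this assay compound 4 gives only a limit, as compound 1 does, so no step between the two can be read: the limit of < 4 ug/mL in this assay, at which 4 of the 4 values shown sit.

The compounds shown leave open the exact value of each one, and whether exchanging the aromatic group on the chain changes the reading in this assay at all.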